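The source may report more compounds than this note shows. Statements on the series, on what has been measured and on what is new or still open speak of the compounds shown alone.

Three compounds of this series were taken through a functional assay on isolated protein for agonist activity at Free fatty acid receptor 1 (Homo sapiens), read by HTRF and inositol phosphate accumulation, with a stated time of 60 min (a lower number here means that less compound is needed, a higher number that more compound is needed for the effect), and none of them produced a number. Compound 1 `O=C(O)CCCOc1ccc(-c2noc3ccccc23)c(Cl)c1Cl` gives > 9950 nM, which is a limit of the assay rather than a measured value. Compound 2 `O=C(O)CCCOc1ccc(-c2cc(-[n+]3ccsc3)ccc2Cl)cc1` likewise stands at > 9950 nM, again only a limit. Compound 3 `O=C(O)c1cc2cc(-c3cc(OC(F)(F)F)ccc3F)ccc2o1` is no different: in this assay compound 3 gives > 9950 nM, a limit as well. All three therefore sit at the same point, (the limit of > 9950 nM in this assay, at which 3 of the 3 values shown sit), so nothing separates them and no ordering among them can be drawn.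

Compound 4 `CC(CC(=O)O)c1cc2cc(-c3cc(OC(F)(F)F)ccc3F)ccc2o1` has not yet been measured. It differs from compound 3 in one place: 1-(carboxymethyl)ethyl in place of carboxy on an aromatic carbon, so the acid is moved out onto a short branched chain while the rest of the molecule is unchanged. For the measured compounds named here, no measured pair shows a change of this kind, and the two compounds that already carry an acid on a chain, compound 1 and compound 2, did not leave the limit either. The expected step is an at least 1.2-fold lower number from compound 3 to compound 4 (0.09 log units; that floor lies within the scatter), a modest move toward a lower concentration at best, with a real chance that this assay again reports only a limit. Compound 4 is estimated at 8000 nM, within a range from 2000 nM to 9950 nM.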

Compound 4, half-maximal effective concentration: > 9950 nM
Compound 4: no number, only a limit (the forecaster's own chance of this, stated with the estimate: 60%); middle value at least 1.2-fold (0.09 log units) away from the limit.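

In this assay compound 4 gives > 9950 nM as a limit and not a number. For the compounds shown here, compound 3 also stands at a limit, so no step between compound 3 and compound 4 can be read, and all four compounds sit together: the limit of > 9950 nM in this assay, at which 4 of the 4 values shown sit. The compounds shown leave open which change, if any, would give a measurable value in this assay and how large it would be.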